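Side-chain amine variation in an adenosine receptor antagonist series

A few compounds are considered here, and "the series" means these few. Any claim that something is new, unique, unknown or untested is made for them only; others in the source may bear on it.

Measured so far, in an assay on CHO-K1 cells for antagonist activity at adenosine receptor A1 (Homo sapiens), read by a beta-galactosidase reporter, with stated times of 15 min and 6 h; on this read-out lower numbers stand for stronger inhibition and higher numbers for weaker inhibition:
Compound 1, `CCN(CC)Cc1cc2c(N)nc(-c3ccco3)nc2s1`, gives 2130 nM.
Compound 2, `Nc1nc(-c2ccco2)nc2sc(CNC3CC3)cc12`, gives 1890 nM.
Compound 3, `Nc1nc(-c2ccco2)nc2sc(CN3CC=CCC3)cc12`, gives 150 nM.

Compound 3 stands lowest of the three numbers in this assay; its steps to the other two compounds are both beyond the scatter, so it is the most potent of the measured set. The step of a 14-fold lower number from compound 1 to compound 3 (1.15 log units; beyond the scatter) and the step of a 13-fold lower number from compound 2 to compound 3 (1.10 log units; beyond the scatter) are both large, whereas the step of a 1.1-fold lower number from compound 1 to compound 2 (0.05 log units; within the scatter) lies within the scatter.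

Compound 4, `Nc1nc(-c2ccco2)nc2sc(CN3CCC(F)(F)CC3)cc12`, is not yet measured. It differs from compound 3 by a group of 8 heavy atoms (5 carbon, 1 nitrogen, 2 fluorine; one six-membered non-aromatic ring with 1 hetero atom) in place of a group of 6 heavy atoms (5 carbon, 1 nitrogen; one six-membered non-aromatic ring with 1 hetero atom), on a saturated chain carbon bound to an aromatic carbon. Both measured large steps arise when a six-membered ring amine replaces an acyclic or three-membered ring amine on the saturated chain carbon; compound 4 keeps a six-membered ring amine at that carbon, so neither of those steps bears directly on the exchange of the ring itself. Within the data shown here, no measured pair shows the effect of fluorine on such a ring. The ring is retained, so the estimate for compound 4 is kept near compound 3, with a step of a 1.7-fold higher number from compound 3 to compound 4 (0.22 log units; within the scatter) expected to stay within or close to the scatter. In this assay compound 4 is expected to give about 250 nM, with a likely range from 80 nM to 800 nM.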

Compound 4, inhibition constant: 2230 nM
Estimate against measurement, compound 4: 8.9-fold (0.95 log units) below, and the stated range ends below it.
By their numbers in this assay, from the lowest: compound 3; then compounds 2, 1 and 4 (each within the scatter of the next).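

In this assay, a six-membered ring amine on the saturated chain carbon does not by itself keep the number low: the exchange of the ring in compound 3 for 4,4-difluoropiperidin-1-yl gives a large step (a 15-fold higher number from compound 3 to compound 4 (1.17 log units; beyond the scatter)), although both rings hold the same count of ring atoms and hetero atoms. The 4,4-difluoropiperidin-1-yl group cannot be told apart from cyclopropylamino (a 1.2-fold higher number from compound 2 to compound 4 (0.07 log units; within the scatter)) or from diethylamino (a 1.0-fold higher number from compound 1 to compound 4 (0.02 log units; within the scatter)), so compound 3 alone stands apart among the four compounds, and the earlier contrast between its ring and the two other amines does not extend to every six-membered ring. No evidence at hand accounts for this result.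

This step both removes a ring double bond and adds two fluorine atoms, so the compounds shown cannot assign the large step to either change alone. An unsubstituted piperidin-1-yl group would stand as the missing link between compound 3 and compound 4, and a morpholin-4-yl group would show how a second ring hetero atom fares at this position.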